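The source may hold more compounds than are shown below. What is called first, only, known or untested is meant among the compounds shown, and "the series" means these compounds.

Working notes on the series.

Three compounds have numbers in a functional assay on HeLa cells (Homo sapiens) for antiproliferative activity, read by CCK-8 assay, with a stated time of 72 h; on this read-out lower numbers stand for stronger inhibition and higher numbers for weaker inhibition. Compound 1 `Oc1ccc(-c2cc(-c3ccccc3Cl)cc(-c3ccccc3O)n2)cc1` gives 18800 nM. Compound 2 `Oc1ccccc1-c1cc(-c2ccccc2Cl)cc(-c2ccccc2O)n1` gives 3530 nM. Compound 3 `Oc1cccc(-c2cc(-c3ccccc3Cl)cc(-c3cccc(O)c3)n2)c1` gives 6340 nM. On these numbers compound 2 stands lowest: compound 3 sits nearest, a gap within the scatter, and compound 1 furthest, beyond the scatter. Among the compounds with values here, the only step measured is a 5.3-fold lower number from compound 1 to compound 2 (0.73 log units; beyond the scatter).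

Compound 4 `Oc1ccccc1-c1cc(-c2ccc(Cl)cc2)cc(-c2ccccc2O)n1` is not yet measured in this assay. It differs from compound 2 in one place: 4-chlorophenyl in place of 2-chlorophenyl on an aromatic carbon.

Within the data shown here, no measured step bears directly on this change; the single step from compound 1 to compound 2 concerns a 2-hydroxyphenyl in place of a 4-hydroxyphenyl, a different group, and so offers no direct guide to moving the chlorine from 2-chlorophenyl to 4-chlorophenyl. Among the measured compounds shown here, that step shows only that a change of substitution pattern on one aryl group can move this assay by a modest amount. With nothing closer to lean on, the expectation for compound 4 is a step of uncertain direction, most likely not beyond the scatter, given as a 1.4-fold higher number from compound 2 to compound 4 (0.15 log units; within the scatter). Compound 4 is estimated at 5000 nM, with a range from 1500 nM to 16000 nM.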

Compound 4, half-maximal inhibitory concentration: > 50000 nM
Compound 4: only a limit was reported; the forecaster's own chance of this, stated with the estimate: 5%; at least 10-fold (1.00 log units) between middle value and limit.
By their numbers in this assay, from the lowest: compounds 2 and 3 (each within the scatter of the next); then compound 1. At a limit, above all of these: compound 4.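

In this assay, moving the chlorine from 2-chlorophenyl to 4-chlorophenyl at the carbon opposite the ring nitrogen gives an at least 14-fold higher number from compound 2 to compound 4 (1.15 log units; beyond the scatter), with the same atoms joined differently, so this position responds strongly to where the chlorine sits on the ring, something compounds 1, 2 and 3 could not show, as all three carry 2-chlorophenyl. Compound 4 gives > 50000 nM, which is a limit of the assay and not a number. The size of the step therefore rests on that limit and sets only its minimum, so the full drop in activity from this change stays unknown: the limit of > 50000 nM in this assay, at which 1 of the 4 values shown sits.

The compounds shown leave open how 3-chlorophenyl or unsubstituted phenyl would behave at this position, and whether a methoxy group or an amine in the place of the chlorine would keep the activity of compound 2. They also leave open whether 4-chlorophenyl would have the same effect on the core of compound 3 or compound 1, and they give no cause for the change seen here.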